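A few compounds are considered here, and "the series" means these few. Any claim that something is new, unique, unknown or untested is made for them only; others in the source may bear on it.

Measured compounds:
compound 1 `CS(=O)(=O)Nc1ccc(-n2cc(COc3ccc([N+](=O)[O-])cc3)nn2)cc1Oc1ccccc1`: "not determined" (no result reported) (no result reported)
compound 2 `CS(=O)(=O)Nc1ccc(-n2cc(OCc3ccccc3)nn2)cc1Oc1ccccc1`: 12300 nM

Within the data shown here, in a functional assay on HepG2 cells (Homo sapiens) for inhibition, read by MTT assay, with a stated time of 48 h (on this read-out lower numbers stand for stronger inhibition and higher numbers for weaker inhibition), compound 2 gives 12300 nM, the only number so far, with compound 1 carrying no result. Compound 3 `CS(=O)(=O)Nc1ccc(-n2cc(-c3ccccc3)nn2)cc1Oc1ccccc1` differs from compound 2 by phenyl in place of benzyloxy on an aromatic carbon. Among the measured compounds shown here, no step between measured compounds is available to anchor the change, so in this assay the step from compound 2 to compound 3 is expected to stay within the usual scatter, in no clear direction. On that basis compound 3 is estimated at 12000 nM, between 4000 nM and 40000 nM, an expected step of a 1.0-fold lower number from compound 2 to compound 3 (0.01 log units; within the scatter).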

Compound 3, half-maximal inhibitory concentration: 13600 nM
The estimate for compound 3 lay 1.1-fold (0.05 log units) below the measured number; measured number inside the range.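

In this assay, the step on this aromatic carbon of the five-membered ring gives the series its first comparison: a 1.1-fold higher number from compound 2 to compound 3 (0.04 log units; within the scatter). Phenyl in place of benzyloxy removes the hydrogen-bond acceptor counted in benzyloxy and keeps a six-membered aromatic ring of carbon only, with no step beyond the scatter in this pair. No measurement at hand gives a reason for this result.

Open, from the compounds shown here alone, is whether an amine or a carboxylic acid at this position would separate from compound 2 and compound 3 in this assay.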